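A seven-membered ring on the sulfonyl sulfur

This account rests on a few compounds, and the source may have more. Where it says the series, first, only, none or still open, it means among the compounds named here.

Measured so far in an ADME assay on cells (Hepatocyte, liver, Mus musculus, strain CD-1) for pharmacokinetics, read by LC-MS, tested at 1 uM; on this read-out lower numbers stand for slow clearance and higher numbers for fast clearance:
- compound 1 `Nc1ccc(CNC(=O)Nc2ccc(S(=O)(=O)c3ccccc3)cc2)cn1` gives 12 mL/min/kg
- compound 2 `C[C@@H]1CN(S(=O)(=O)c2ccc(NC(=O)NCc3cccnc3)cc2)C[C@H](C)O1` gives 55 mL/min/kg
- compound 3 `O=C(NCc1cccnc1)Nc1ccc(S(=O)(=O)N2CCC3(CCNC3)CC2)cc1` gives 9.2 mL/min/kg

Compound 3 sits at the low end of this small set. Its number lies within the scatter of that of compound 1, while compound 2 stands well clear of both.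

The next compound is compound 4 `CC1CNCCN(S(=O)(=O)c2ccc(NC(=O)NCc3cccnc3)cc2)C1`, which differs from compound 3 in one place: a group of 8 heavy atoms (6 carbon, 2 nitrogen; one seven-membered non-aromatic ring with 2 hetero atoms) in place of a group of 10 heavy atoms (8 carbon, 2 nitrogen; one five-membered non-aromatic ring with 1 hetero atom, one six-membered non-aromatic ring with 1 hetero atom), on a sulfonyl sulfur. The entering group is a seven-membered non-aromatic ring with 2 hetero atoms, and like the leaving group it has no net charge.

Within the data shown here, only one measured step bears on this change, and it falls at the same sulfonyl sulfur: a 6.0-fold lower number from compound 2 to compound 3 (0.78 log units; beyond the scatter). That step lies beyond the scatter, so a swap at this place can move the number, and the range here is kept wide. However, the group of compound 2 holds an oxygen, and neither group in the present change does. No shift beyond the scatter is therefore expected in this assay.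

The expected change is a 1.3-fold higher number from compound 3 to compound 4 (0.12 log units; within the scatter). For compound 4 the estimated clearance is 12 mL/min/kg, with an expected range of 6 mL/min/kg to 26 mL/min/kg.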

Compound 4, clearance: 16 mL/min/kg
Compound 4: the middle estimate sits 1.3-fold (0.12 log units) below what was measured; the measured number falls inside the stated range.
By their numbers in this assay, from the lowest: compounds 3, 1 and 4 (each within the scatter of the next); then compound 2.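

In this assay, the seven-membered non-aromatic ring with 2 hetero atoms on the sulfonyl sulfur reads much like the group with a five-membered and a six-membered non-aromatic ring, with a 1.7-fold higher number from compound 3 to compound 4 (0.24 log units; within the scatter), so a change of ring form and heavy-atom count between these two groups, each with 2 nitrogen atoms, does not separate them in this read-out. Set against the oxygen-containing six-membered ring of compound 2, the same seven-membered ring gives a 3.4-fold lower number from compound 2 to compound 4 (0.54 log units; beyond the scatter), so compound 2 now stands apart from two different nitrogen-containing groups at this position, although this pattern rests on only three compounds. Nothing among the available data explains why the oxygen-containing group stands apart from the other two.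

On these data alone, it remains open whether a plain morpholine, without the methyl groups of compound 2, would read with compound 2 or with compound 3 and compound 4, and a piperazine would pose the same question from the other side. Also open, as far as these compounds go, is how the number would respond to an acetyl group on the ring nitrogen of compound 4.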